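Aryl ring change from compound 2 to compound 4

The source may hold more compounds than are shown below. What is called first, only, known or untested is meant among the compounds shown, and "the series" means these compounds.

Compound 2 `COc1ccc(C(=O)/C=C/c2cccc([N+](=O)[O-])c2)c2c1C=CC(C)(C)O2` gives 5870 nM in a functional assay on K562 cells (Homo sapiens) for antiproliferative activity, read by MTT assay, with a stated time of 24 h (on this read-out higher numbers stand for weaker inhibition and lower numbers for stronger inhibition), the lowest of the two numbers in hand. Compound 3 `COc1ccc(C(=O)/C=C/c2cccc(C(F)(F)F)c2)c2c1C=CC(C)(C)O2` gives 7850 nM, and the step of a 1.3-fold higher number from compound 2 to compound 3 (0.13 log units; within the scatter) lies within the scatter. Compound 1 `COc1ccc(C(=O)/C=C/c2ccc(N(c3ccccc3)c3ccccc3)cc2)c2c1C=CC(C)(C)O2` reaches only the assay limit > 10000 nM in this assay. That limit, (the limit of > 10000 nM in this assay, at which 1 of the 3 values shown sits), is the single limit among the three values. Compound 4 `COc1ccc(C(=O)/C=C/c2ccc(O)c(Br)c2)c2c1C=CC(C)(C)O2` is not yet measured. Its change from compound 2 is 3-bromo-4-hydroxyphenyl in place of 3-nitrophenyl on a double-bonded chain carbon bound to a double-bonded chain carbon. For the measured compounds named here, no measured step covers this change: the only step in hand swaps trifluoromethyl for nitro and sits within the scatter, so no direction beyond the scatter is indicated. Compound 4 is therefore expected near 4500 nM in this assay, with a range from 1500 nM to 12000 nM. The step of a 1.3-fold lower number from compound 2 to compound 4 (0.12 log units; within the scatter) is expected to stay within the scatter.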

Compound 4, half-maximal inhibitory concentration: > 10000 nM
Compound 4 was reported as a limit; the forecaster's own chance of this, stated with the estimate: 25%; at least 2.2-fold (0.34 log units) between middle value and limit.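

For the compounds shown here, this is the first change on the double-bonded chain carbon to bring in a hydrogen-bond donor, and in this assay it gives no lower number: an at least 1.7-fold higher number from compound 2 to compound 4 (0.23 log units; that floor lies within the scatter). On these data alone, the size of that step stays unknown, as compound 4 is a limit and not a number. Compound 4 joins compound 1 at that limit: the limit of > 10000 nM in this assay, at which 2 of the 4 values shown sit.

As far as these compounds go, whether bromine alone or hydroxyl alone would read the same stays open. Also open, from the compounds shown here alone, is how an amine or a carboxylic acid on this aromatic ring would read.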